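The compounds below may be only part of what the source reports. "The series", "measured", "known", "first", "only" and "open" are said of these compounds alone.

Measured so far in a functional assay on CHO-K1 cells for antagonist activity at transient receptor potential cation channel subfamily V member 1 (Homo sapiens), read by FLIPR; a higher number here means a weaker inhibitor, a lower number a stronger inhibitor:
compound 1 `CC(C(=O)NCc1ccc(C(F)(F)F)nc1Nc1ccc(F)cc1)c1ccc(NS(C)(=O)=O)c(F)c1`: 39.2 nM
compound 2 `Cc1ccc(Nc2nc(C(F)(F)F)ccc2CNC(=O)C(C)c2ccc(NS(C)(=O)=O)c(F)c2)cc1C`: 39.3 nM
compound 3 `CC(C(=O)NCc1ccc(C(F)(F)F)nc1N1CCC(c2ccccc2)CC1)c1ccc(NS(C)(=O)=O)c(F)c1`: 0.6 nM

Compound 2 gives the highest number of the three, but its value and that of compound 1 lie within the scatter of each other; the step of a 1.0-fold higher number from compound 1 to compound 2 (0.00 log units; within the scatter) shows no difference. Compound 3 stands far apart: a 66-fold lower number from compound 2 to compound 3 (1.82 log units; beyond the scatter) and a 65-fold lower number from compound 1 to compound 3 (1.82 log units; beyond the scatter) are both large, while compound 1 and compound 2 give near-identical numbers.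

Compound 4 `CC(C(=O)NCc1ccc(C(F)(F)F)nc1N1CCC(C(F)(F)F)CC1)c1ccc(NS(C)(=O)=O)c(F)c1` is not yet measured. The change from compound 2 is 4-(trifluoromethyl)piperidin-1-yl in place of (3,4-dimethylphenyl)amino on an aromatic carbon. The place of the change is the same aromatic carbon, next to the ring nitrogen, at which compound 3 carries the 4-phenylpiperidin-1-yl group. The step of a 66-fold lower number from compound 2 to compound 3 (1.82 log units; beyond the scatter) bears on it directly: exchanging the (3,4-dimethylphenyl)amino group for a 4-phenylpiperidin-1-yl group gave a large lowering of the number. Within the data shown here, whether a 4-(trifluoromethyl)piperidin-1-yl group behaves like the 4-phenylpiperidin-1-yl group of compound 3 cannot be read from these three compounds; no measured pair varies that part. A step in the same direction as a 66-fold lower number from compound 2 to compound 3 (1.82 log units; beyond the scatter) is therefore expected, with a wider range than that step alone would suggest. The expected step is a 13-fold lower number from compound 2 to compound 4 (1.12 log units; beyond the scatter). Compound 4 is expected to give 3 nM, between 0.6 nM and 15 nM.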

Compound 4, inhibition constant: 0.6 nM
The estimate for compound 4 lay 5.0-fold (0.70 log units) above the measured number; the measured number falls inside the stated range.
By their numbers in this assay, from the lowest: compounds 3 and 4 (each within the scatter of the next); then compounds 1 and 2 (each within the scatter of the next).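

In this assay, the large lowering of the number at the aromatic carbon next to the ring nitrogen is no longer tied to one group: a 66-fold lower number from compound 2 to compound 4 (1.82 log units; beyond the scatter) and a 65-fold lower number from compound 1 to compound 4 (1.82 log units; beyond the scatter) show it again with 4-(trifluoromethyl)piperidin-1-yl, so two piperidin-1-yl groups now stand against two arylamino groups. The group carried on the saturated ring carbon does not separate the two piperidines, as no change at the digits printed from compound 3 to compound 4 (within the scatter) shows for trifluoromethyl in place of phenyl, even though one of these groups contains an aromatic ring and the other contains only carbon and fluorine. No supporting measurement is available to explain these steps.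

The exchange of an arylamino group for a piperidin-1-yl group changes both the ring and the count of hydrogen-bond donors, so a (4-fluorophenyl)(methyl)amino group at the same carbon would be needed to tell these two changes apart. How far the tolerance on the saturated ring carbon extends also stays open, as neither an unsubstituted piperidin-1-yl group nor a piperidine carrying a carboxylic acid or a primary amine at that carbon is among the compounds shown.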